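From 2-methoxyphenyl to 3-hydroxyphenyl at an assay limit

The compounds below may be only part of what the source reports. "The series", "measured", "known", "first", "only" and "open" are said of these compounds alone.

Measured compounds in a functional assay on A549 cells (Homo sapiens) for cytotoxicity, read by MTT assay, with a stated time of 72 h (a lower number here means a stronger inhibitor, a higher number a weaker inhibitor), and their values
- compound 1 `COc1cccc(/C=C2\CCC/C(=C\c3cccc(Cl)c3)C2=O)c1OC` gives the limit > 20000 nM
- compound 2 `COc1cccc(/C=C2\CCC/C(=C\c3ccc(Cl)cc3)C2=O)c1OC` gives the limit > 20000 nM
- compound 3 `COc1ccccc1/C=C1\CCC/C(=C\c2cccc(OC)c2OC)C1=O` gives the limit > 20000 nM

Compound 3 has no exact number: its entry of > 20000 nM is a limit. It shares that position with the other two compounds (the limit of > 20000 nM in this assay, at which 3 of the 3 values shown sit), so the data cannot rank them.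

The next compound is compound 4 `COc1cccc(/C=C2\CCC/C(=C\c3cccc(O)c3)C2=O)c1OC`. It carries 3-hydroxyphenyl in place of 2-methoxyphenyl on a double-bonded chain carbon bound to a double-bonded ring carbon.

Changes at this same place were measured as (a step that the two limits leave unreadable from compound 1 to compound 2), (a step that the two limits leave unreadable from compound 1 to compound 3) and (a step that the two limits leave unreadable from compound 2 to compound 3). None has a readable size, so they set no direction. Compound 4 is therefore expected to stay weak in this assay and close to the limit, with only a small expected move toward stronger inhibition (an at least 1.3-fold lower number from compound 3 to compound 4 (0.12 log units; that floor lies within the scatter)). The estimated value for compound 4 is 15000 nM with an expected range of 5000 nM to 20000 nM as a rough guide.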

Compound 4, half-maximal inhibitory concentration: > 20000 nM
Compound 4 was reported as a limit (the forecaster's own chance of this, stated with the estimate: 50%); middle value at least 1.3-fold (0.12 log units) away from the limit.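

Compound 4 gives > 20000 nM, which is a limit and not a number. No step among compound 1, compound 2, compound 3 and compound 4 can be read, because all four sit at the same limit: the limit of > 20000 nM in this assay, at which 4 of the 4 values shown sit.

The compounds shown leave open how these four rank against one another.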